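Trifluoromethyl in Place of Hydrogen: Estimating Compound 3

This account rests on a few compounds, and the source may have more. Where it says the series, first, only, none or still open, it means among the compounds named here.

In an ADME assay on MDCK cells (Canis lupus familiaris) for cytotoxicity (on this read-out lower numbers stand for higher toxicity in this test and higher numbers for lower toxicity in this test), compound 1 (`O=[N+]([O-])C1=NNc2ncnn2C1c1ccc(O)c(O)c1`) reads > 1630000 nM as a limit of the assay and not a number. Its place is the limit of > 1630000 nM in this assay, at which 1 of the 2 values shown sits, among these data. Compound 2 (`O=[N+]([O-])C1=CNc2nc(C(F)(F)F)nn2C1c1c(O)cc(O)cc1O`), which also bears trifluoromethyl, gives 838000 nM as a measured number. Compound 3 (`O=[N+]([O-])C1=NNc2nc(C(F)(F)F)nn2C1c1ccc(O)c(O)c1`) has not yet been measured. The change from compound 1 to compound 3 is trifluoromethyl in place of hydrogen on an aromatic carbon. For the measured compounds named here, no measured step between closely matched compounds is available, so a modest fall in this assay is expected, towards higher toxicity, resting only on compound 2 at 838000 nM in this comparison. The expected change is an at least 1.6-fold lower number from compound 1 to compound 3 (0.21 log units; that floor lies within the scatter) on this estimate. For compound 3 the expected half-maximal cytotoxic concentration is 1000000 nM (estimated range 450000 nM to 2000000 nM).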

Compound 3, half-maximal cytotoxic concentration: 183000 nM
Compound 3: the middle estimate sits 5.5-fold (0.74 log units) above what was measured; measured number below the stated range.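

In this assay, for the compounds shown here, trifluoromethyl in place of hydrogen on an aromatic carbon, between two ring nitrogen atoms, gives an at least 8.9-fold lower number from compound 1 to compound 3 (0.94 log units; beyond the scatter), the first measured step at this position. It shows that this single change on the core of compound 1 moves the read-out towards higher toxicity in this test by more than the usual scatter. The size of the step is only a floor, because compound 1 stands at a limit of the assay and not at a number: the limit of > 1630000 nM in this assay, at which 1 of the 3 values shown sits.

The compounds shown leave open how far the true step runs past that floor. They also leave open whether a methyl group, an amine or a carboxylic acid on this same carbon would lower the number as far as trifluoromethyl does.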